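Adding a Second Chloro Group to Compound 2

The compounds below may be only part of what the source reports. "The series", "measured", "known", "first", "only" and "open" are said of these compounds alone.

Of the compounds shown here, three of a shared core have been measured in an assay on HL-60 cells for inhibition of glutathione S-transferase P (Homo sapiens), read by spectrophotometry, tested at 5 uM; a higher number here means more inhibition at the concentration tested (going by the name of the read-out), a lower number less inhibition. Compound 1 `C=C(CC)C(=O)c1ccc(OCc2nc(-c3ccc4ccccc4c3)cs2)cc1Cl` gives 9.5%. Compound 2 `C=C(CC)C(=O)c1ccc(OCc2nc(-c3ccc(C(F)(F)F)cc3)cs2)cc1Cl` gives 19.7%, and compound 3 `C=C(C)C(=O)c1ccc(OCc2nc(-c3ccc(C(F)(F)F)cc3)cs2)cc1Cl` gives 72.3%. Compound 2 thus stands second highest of the three numbers: its nearest neighbour is compound 1, and the step of a number 10.2 percentage points higher from compound 1 to compound 2 (beyond the scatter); its furthest is compound 3, and the step of a number 52.6 percentage points higher from compound 2 to compound 3 (beyond the scatter).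

Compound 4 `C=C(CC)C(=O)c1ccc(OCc2nc(-c3ccc(C(F)(F)F)cc3)cs2)c(Cl)c1Cl` has not yet been measured. It differs from compound 2 in one place: chloro in place of hydrogen on an aromatic carbon. The new chloro group enters ortho to the chloro group already present, ortho to a large group, and meta to a group of 6 heavy atoms.

Neither measured step touches this part of the core. The step from compound 1 to compound 2 changes the aryl group on the far ring, and the step from compound 2 to compound 3 changes the chain carbon bound to the double-bonded carbon. Among the compounds with values here, no measured step therefore bears directly on the change from compound 2 to compound 4, and the expectation is of a step within the scatter, a number 2.3 percentage points higher from compound 2 to compound 4 (within the scatter). Compound 4 is estimated at 22%, within 6% to 45%.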

Compound 4, a percentage reported as inhibition, at one concentration (the size of the read-out at that concentration, not a potency): 22.2%
Beside the measured number, compound 4's estimate is 0.2 percentage points below it; low and high end bracket the measured number.
By their numbers in this assay, from the lowest: compound 1; then compounds 2 and 4 (each within the scatter of the next); then compound 3.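

In this assay, chloro in place of hydrogen on this aromatic carbon gives a number 2.5 percentage points higher from compound 2 to compound 4 (within the scatter), so the two compounds cannot be told apart at the concentration tested. Within the data shown here, a second chloro group at this place, ortho to a chloro group, ortho to a large group and meta to a group of 6 heavy atoms, therefore leaves the read-out unchanged within the scatter in the one pair available, whereas a number 10.2 percentage points higher from compound 1 to compound 2 (beyond the scatter) and a number 52.6 percentage points higher from compound 2 to compound 3 (beyond the scatter), at other places on the shared core, both lie beyond it. The data on hand offer no measurement that would account for this outcome.

What the compounds shown leave open is whether a different group on the same aromatic carbon, such as an amine, a methoxy group or a carboxylic acid, would also stay within the scatter of compound 2. On these data alone, it also remains open whether a second chloro group would behave in the same way on the shorter chain of compound 3, which gives 72.3%, since this change has been read only with the chain of compound 2.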